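From hydroxy to butoxy on a bromo compound

A few compounds are considered here, and "the series" means these few. Any claim that something is new, unique, unknown or untested is made for them only; others in the source may bear on it.

Measured in a functional assay on MCF7 cells (Homo sapiens) for cytotoxicity, read by MTT assay; on this read-out higher numbers stand for weaker inhibition and lower numbers for stronger inhibition
compound 1 `COc1cc(/C=C2\CCC/C(=C\c3ccc([N+](=O)[O-])cc3)C2=O)ccc1O` gives 7.05 ug/mL
compound 2 `COc1cc(/C=C2\CCC/C(=C\c3ccc([N+](=O)[O-])cc3)C2=O)cc(Br)c1O` gives 4.93 ug/mL

Compound 2 stands at 4.93 ug/mL and cannot be told apart from compound 1 at 7.05 ug/mL on these numbers. The next compound, compound 3 `CCCCOc1c(Br)cc(/C=C2\CCC/C(=C\c3ccc([N+](=O)[O-])cc3)C2=O)cc1OC` keeps everything else in compound 2 and differs by butyl in place of hydrogen on an oxygen on an aromatic ring in the change from hydroxy to butoxy, which is butyl in place of hydrogen on an oxygen on an aromatic ring.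

Among the compounds with values here, only one measured step is available. It is a 1.4-fold lower number from compound 1 to compound 2 (0.16 log units; within the scatter) and lies within the scatter. That step is bromo in place of hydrogen on an aromatic carbon, a different change in a different place, so it bears only loosely on this one. Within the data shown here, no measured step shows what a group on that oxygen does in this assay and the data offer no direct guide. With compound 2 at 4.93 ug/mL as the starting point, no shift beyond the scatter is expected, though the uncertainty is wide. The expected step is a 1.2-fold higher number from compound 2 to compound 3 (0.09 log units; within the scatter) and so stays within the scatter. Compound 3 is estimated at 6 ug/mL with an expected range from 2 ug/mL to 18 ug/mL as a working figure.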

Compound 3, half-maximal inhibitory concentration: 27 ug/mL
Beside the measured number, compound 3's estimate is 4.5-fold (0.65 log units) below it; the measured number lies above the stated range.
By their numbers in this assay, from the lowest: compounds 2 and 1 (each within the scatter of the next); then compound 3.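

In this assay, within the data shown here, the change from hydroxy to butoxy on this oxygen is the first step to go beyond the scatter, with a 5.5-fold higher number from compound 2 to compound 3 (0.74 log units; beyond the scatter) on an otherwise unchanged core. The only earlier step, a 1.4-fold lower number from compound 1 to compound 2 (0.16 log units; within the scatter), changed a different place and stayed within the scatter, so this oxygen on an aromatic ring is the one place shown where a single change moves the number clearly, and the move is towards weaker inhibition. Nothing available here accounts for the size or direction of this step.

With butyl as the only group on this oxygen, the compounds shown cannot separate the effect of removing the hydroxy hydrogen from the effect of the chain that replaces it. A small ethyl group, or a butyl chain ending in an amine or a carboxylic acid, would show whether the number rises with any group on this oxygen or depends on which group stands there, and a butoxy partner for compound 1 would show whether the step holds without the bromo group.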